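This account rests on a few compounds, and the source may have more. Where it says the series, first, only, none or still open, it means among the compounds named here.

Three amides sharing one core were compared in a functional assay on HCT-116 cells (Homo sapiens) for inhibition, read by CCK-8 assay, with a stated time of 72 h, tested at 2 uM; a higher number here means more inhibition of growth at the concentration tested, a lower number less inhibition of growth. Compound 1 `COc1ccc(SCc2ccc(C(=O)Nc3ccccc3N)cc2)cc1` gives 73.3% in this assay. Compound 2 `Nc1ccccc1NC(=O)c1ccc(CSc2cccc(F)c2)cc1` gives 5.5%. Compound 3 `Cc1cc(C)cc(SCc2ccc(C(=O)Nc3ccccc3N)cc2)c1` gives 3.22%, the lowest of the three numbers; the nearest is compound 2, within the scatter, and the furthest is compound 1, well beyond it. The two aryl exchanges on the sulfur that lead away from compound 1 are both large: a number 67.8 percentage points lower from compound 1 to compound 2 (beyond the scatter) and a number 70.1 percentage points lower from compound 1 to compound 3 (beyond the scatter), while a number 2.3 percentage points lower from compound 2 to compound 3 (within the scatter).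

Compound 4 `Nc1ccccc1NC(=O)c1ccc(CSc2ccc(F)cc2)cc1` is the next member, differing from compound 3 by 4-fluorophenyl in place of 3,5-dimethylphenyl on a sulfur. Within the data shown here, the steps that bear on it are the three already measured: the one fluorine-bearing aryl group, in compound 2, sits at the low end together with compound 3, and only the methoxy-bearing aryl group of compound 1 stands high. On this basis a small step is expected, a number 11.8 percentage points higher from compound 3 to compound 4 (beyond the scatter), with compound 4 remaining near the level of compound 2 and compound 3; a rise toward compound 1 cannot be excluded, since only one high point exists, so the range is kept wide. Compound 4 is therefore estimated at 15%, between 1% and 60%, in this assay.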

Compound 4, percent growth inhibition at one concentration: 13.5%
For compound 4 the middle estimate is 1.5 percentage points above the measured one; low and high end bracket the measured number.
By their numbers in this assay, from the lowest: compounds 3, 2 and 4 (each within the scatter of the next, the first and the last beyond it); then compound 1.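

The exchange at this place shows that the high number of compound 1 does not carry over to every aryl group with a single group in the 4-position: with fluoro in place of methoxy on an aromatic carbon, the change is a number 59.8 percentage points lower from compound 1 to compound 4 (beyond the scatter) in this assay and compound 4 stays far from compound 1. Moving the fluorine makes no clear difference, since 4-fluorophenyl in place of 3-fluorophenyl on the sulfur gives a number 8 percentage points higher from compound 2 to compound 4 (within the scatter) and so leaves these two compounds level, while 4-fluorophenyl in place of 3,5-dimethylphenyl gives only a number 10.3 percentage points higher from compound 3 to compound 4 (beyond the scatter) and stays small beside the gap to compound 1. Nothing shown here accounts for the large difference between the methoxy and fluoro compounds.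

From the compounds shown here alone, with compound 1 as the only high point, it remains open whether an ethoxy group, a hydroxyl group or a dimethylamino group in place of the methoxy group would hold that level, or whether methoxy alone does so. The compounds shown also leave open how a 3-methoxyphenyl or a 4-chlorophenyl group on the same sulfur would compare.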